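Piperazine sulfonamide series: distal aryl substituent swap

The source may report more compounds than this note shows. Statements on the series, on what has been measured and on what is new or still open speak of the compounds shown alone.

Measured so far in a functional assay on PC-3 cells (Homo sapiens) for inhibition; a higher number here means a weaker inhibitor, a lower number a stronger inhibitor:
- compound 1 `COc1cc2nc(N3CCN(S(=O)(=O)c4ccc(Cl)cc4)CC3)nc(N)c2cc1OC` gives 23000 nM
- compound 2 `COc1cc2nc(N3CCN(S(=O)(=O)c4ccc(-c5ccc(S(C)(=O)=O)cc5)cc4)CC3)nc(N)c2cc1OC` gives 7200 nM

Among the compounds with values here, compound 2 holds the lowest of the two numbers, with compound 1 the nearest neighbour at a 3.2-fold lower number from compound 1 to compound 2 (0.50 log units; beyond the scatter), the only step measured in this assay. Compound 3 `COc1cc2nc(N3CCN(S(=O)(=O)c4ccc(-c5ccc(C(C)(C)C)cc5)cc4)CC3)nc(N)c2cc1OC` is the next compound, differing from compound 2 by tert-butyl in place of methylsulfonyl on an aromatic carbon. Within the data shown here, the single measured step concerns adding the whole outer ring to compound 1, not exchanging a group on it, so it offers no direct guide; no step within the scatter or beyond it is known for this kind of swap. Compound 3 is therefore expected to stay near compound 2, with a 1.1-fold higher number from compound 2 to compound 3 (0.05 log units; within the scatter) as the estimated step. The estimate for compound 3 is 8000 nM, within 2500 nM to 25000 nM.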

Compound 3, half-maximal inhibitory concentration: 10000 nM
Compound 3: middle estimate off by 1.3-fold (0.10 log units), on the low side; the measured number falls inside the stated range.
By their numbers in this assay, from the lowest: compounds 2 and 3 (each within the scatter of the next); then compound 1.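

In this assay, tert-butyl for methylsulfonyl on the outer ring gives a 1.4-fold higher number from compound 2 to compound 3 (0.14 log units; within the scatter), so at this place, para to a large group, the change from a group with hydrogen-bond acceptors to one without leaves the number within the scatter. Against chloro, the 4-(tert-butyl)phenyl group still gives a 2.3-fold lower number from compound 1 to compound 3 (0.36 log units; beyond the scatter), a modest step beyond the scatter. Open, on these data alone, is whether an amine or a carboxylic acid on this outer ring would move the number beyond the scatter from compound 2. Nothing available bears on why these steps have the sizes they do.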